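Benzamidomethyl in place of phenyl on the shared core

The source may report more compounds than this note shows. Statements on the series, on what has been measured and on what is new or still open speak of the compounds shown alone.

In a functional assay on A-431 cells (Homo sapiens) for inhibition, read by MTT assay, with a stated time of 72 h (a higher number here means a weaker inhibitor, a lower number a stronger inhibitor), compound 3 `c1ccc(-c2nnc(SCCCN3CCN(c4nc5ccccc5o4)CC3)o2)cc1` stands at 57600 nM and is level, within the scatter, with compound 1 `O=[N+]([O-])c1ccc(-c2nnc(SCCCN3CCN(c4nc5ccccc5o4)CC3)o2)cc1` at 46900 nM and compound 2 `CC(C)(C)Oc1ccc(-c2nnc(SCCCN3CCN(c4nc5ccccc5o4)CC3)o2)cc1` at 65800 nM on the same core. The steps reaching compound 3 are small: a 1.2-fold higher number from compound 1 to compound 3 (0.09 log units; within the scatter) and a 1.1-fold lower number from compound 2 to compound 3 (0.06 log units; within the scatter) are both within the scatter, as is a 1.4-fold higher number from compound 1 to compound 2 (0.15 log units; within the scatter) among the two substituted members.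

Compound 4 `O=C(NCc1nnc(SCCCN2CCN(c3nc4ccccc4o3)CC2)o1)c1ccccc1` brings a different kind of change: benzamidomethyl in place of phenyl on an aromatic carbon with benzamidomethyl in place of phenyl on an aromatic carbon of the five-membered aromatic ring with 2 nitrogen and 1 oxygen.

For the measured compounds named here, none of the measured steps replaces the phenyl itself. All three only exchange nitro, tert-butoxy and hydrogen on an aromatic carbon of that group, so they bear on this change only indirectly. Going by the values given here, the data hold no step at this place and therefore show no direction. With a 1.1-fold lower number from compound 2 to compound 3 (0.06 log units; within the scatter) as the kind of step seen so far, no step beyond the scatter is expected. The estimated step runs a 1.0-fold lower number from compound 3 to compound 4 (0.02 log units; within the scatter) and is no more than a working expectation. For compound 4 the expected value is 55000 nM within a range of 22000 nM to 120000 nM in this assay at this stage.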

Compound 4, half-maximal inhibitory concentration: 36900 nM
Beside the measured number, compound 4's estimate is 1.5-fold (0.17 log units) above it, and the stated range covers the measured number.
By their numbers in this assay, from the lowest: compounds 4, 1, 3 and 2 (each within the scatter of the next).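

For the compounds shown here, compound 4 is the first member in which the phenyl itself is replaced rather than substituted, and in this assay this exchange stays within the scatter: a 1.6-fold lower number from compound 3 to compound 4 (0.19 log units; within the scatter), with a 1.8-fold lower number from compound 2 to compound 4 (0.25 log units; within the scatter) and a 1.3-fold lower number from compound 1 to compound 4 (0.10 log units; within the scatter) when the substituted phenyls are the starting point. This aromatic carbon of the five-membered ring therefore carries benzamidomethyl, with its carbonyl and amide hydrogen, as well as the three phenyl groups without any step beyond the scatter, so the measured range of the series extends from substituent exchange on the phenyl to replacement of the whole group. Nothing at hand accounts for these numbers or links them to any feature of the groups.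

Open, on these data alone, is whether a group without the amide, such as benzyl, or one without the terminal aromatic ring, such as aminomethyl or a carboxylic acid, would also stay level with these four compounds at this place. Also open is whether a longer chain between the amide and the five-membered ring would produce a step beyond the scatter, which no pair shown here does.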